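The source may hold more compounds than are shown below. What is called first, only, known or untested is meant among the compounds shown, and "the series" means these compounds.

Working notes on the series. Two compounds have numbers in a physicochemical assay for solubility, read by LC-MS, in phosphate buffer, measured as kinetic solubility, with a stated time of 2 h, at pH 7.4; a higher number here means a more soluble compound, a lower number a less soluble compound. Compound 1 `Cc1ccc(-c2cn(CCN3CCCC3)nn2)c(NC(=O)c2cc(=O)c3ccccc3o2)c1` gives 7000 nM in this assay. Compound 2 `CCC(=O)c1ccc(-c2cn(CC(=O)O)nn2)cc1NC(=O)c1cc(=O)c2ccccc2o1` gives 10000 nM in this assay, the higher of the two numbers; the gap to compound 1 is within the scatter, so nothing separates the two on these figures.

Compound 3 `CCC(=O)c1ccc(-c2cn(CCN3CCCC3)nn2)cc1NC(=O)c1cc(=O)c2ccccc2o1` has not been measured in this assay. Relative to compound 2 it differs in one place: (pyrrolidin-1-yl)methyl in place of carboxy on a saturated chain carbon bound to an aromatic nitrogen. Among the compounds with values here, no step between measured compounds covers this change on its own, so its effect is not known from a direct comparison.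

For compound 3 no step beyond the scatter is expected in this assay, since compound 1, which already carries the 2-(pyrrolidin-1-yl)ethyl chain on the triazole, gives 7000 nM and compound 2, which carries the carboxymethyl chain, gives 10000 nM. The number for compound 3 in this assay is expected to be 7000 nM, with a range of 3000 nM to 15000 nM. The step that this estimate means is expected to be a 1.4-fold lower number from compound 2 to compound 3 (0.15 log units; within the scatter), within the scatter.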

Compound 3, solubility: 30000 nM
Beside the measured number, compound 3's estimate is 4.3-fold (0.63 log units) below it; the measured number lies above the stated range.
By their numbers in this assay, from the lowest: compounds 1 and 2 (each within the scatter of the next); then compound 3.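

In this assay, the change from carboxymethyl to 2-(pyrrolidin-1-yl)ethyl, on a saturated chain carbon bound to an aromatic nitrogen, gives a 3.0-fold higher number from compound 2 to compound 3 (0.48 log units; beyond the scatter). Within the data shown here, this is the first direct reading of a change at this place and the first step beyond the scatter, so the number in this assay responds to what this chain carries when the rest of the structure stays the same. The compounds offer no independent measurement that accounts for the size or direction of the step.

On these data alone, it remains open whether the step follows the arrival of the pyrrolidine ring, the departure of the carboxy group or both, a question that a dimethylamino or morpholine group at the chain end, a methyl ester or primary amide in place of the carboxy group, or a longer chain could help separate. This change also rests on a single pair, so whether it carries over to the core of compound 1, with its methyl group in place of the propanoyl group, is unresolved.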